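The source may report more compounds than this note shows. Statements on the series, on what has been measured and on what is new or still open speak of the compounds shown alone.

Compound 1 `C=CCn1c(=O)/c(=C\c2ccccc2Cl)[nH]c(=O)/c1=C\c1ccccc1OC`, in a functional assay on U-937 cells (Homo sapiens) for cytotoxicity, read by CCK-8 assay, with a stated time of 72 h (a higher number here means a weaker inhibitor, a lower number a stronger inhibitor), gives 700 nM.
Compound 2 `C=CCn1c(=O)/c(=C\c2ccccc2OC)[nH]c(=O)/c1=C\c1ccccc1OC`, in this assay, gives 5100 nM.

Going by the values given here, of the two numbers measured so far, compound 2 carries the higher one, which makes it the weaker inhibitor of the pair; the single step that separates the two, a 7.3-fold higher number from compound 1 to compound 2 (0.86 log units; beyond the scatter), lies beyond the scatter. Compound 3 `C=CCn1c(=O)/c(=C\c2ccccc2C(F)(F)F)[nH]c(=O)/c1=C\c1ccccc1OC` has not yet been measured. It arises from compound 2 by one change: trifluoromethyl in place of methoxy on an aromatic carbon. Among the compounds with values here, no measured step exchanges methoxy for trifluoromethyl, so the only guide is a 7.3-fold higher number from compound 1 to compound 2 (0.86 log units; beyond the scatter), in which the methoxy that compound 3 also loses was the group that came in, and the number rose. Read backwards, removing that methoxy is the direction that has so far gone with a lower number, though the data say nothing about whether trifluoromethyl will behave like chloro. On that basis a modest lowering of the number for compound 3 is expected, a 3.4-fold lower number from compound 2 to compound 3 (0.53 log units; beyond the scatter), with a wide range around it. Compound 3 is therefore estimated at 1500 nM, expected to fall between 400 nM and 6000 nM.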

Compound 3, half-maximal inhibitory concentration: 1500 nM
Compound 3: the middle estimate sits on the measured number at the digits printed, and the stated range covers the measured number.
By their numbers in this assay, from the lowest: compound 1; then compound 3; then compound 2.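

In this assay, trifluoromethyl in place of methoxy on this aromatic carbon gives a 3.4-fold lower number from compound 2 to compound 3 (0.53 log units; beyond the scatter), so the lower number seen without the methoxy now appears with a second group and not only with chloro. The two replacements are not equivalent, however: trifluoromethyl in place of chloro gives a 2.1-fold higher number from compound 1 to compound 3 (0.33 log units; beyond the scatter), a small step but one printed as beyond the scatter, so this single position separates all three groups, with chloro giving the lowest number, trifluoromethyl the middle one and methoxy the highest. Nothing measured here explains why the three groups fall in this order.

On these data alone, these three compounds test only one place on the molecule, so it remains open how a bare hydrogen, an amine or a carboxylic acid on this same carbon would compare with chloro. As far as these compounds go, all three also share the other 2-methoxyphenyl group and the allyl chain, so it is equally open whether this order would hold if that methoxy became chloro or the allyl became a longer chain.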